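The source may hold more compounds than are shown below. What is called first, only, known or untested is meant among the compounds shown, and "the series" means these compounds.

Measured so far in a functional assay on A549 cells (Homo sapiens) for inhibition, read by MTT assay and WST assay, with a stated time of 72 h, tested at 10 uM; a lower number here means less inhibition of growth, a higher number more inhibition of growth at the concentration tested:
compound 1 `O=C(Nc1ccc(Oc2ccc(-c3nccs3)cc2)cc1)Nc1ccc(Cl)c([N+](=O)[O-])c1`, 77.1%
compound 2 `O=C(Nc1ccc(Oc2ccc(-c3ncc[nH]3)cc2)cc1)Nc1ccc(Cl)c([N+](=O)[O-])c1`, 12.4%

Among the compounds with values here, compound 2 stands lowest of the two numbers; its nearest neighbour is compound 1, and the only counted step, a number 64.7 percentage points lower from compound 1 to compound 2 (beyond the scatter), concerns the ring at the far end of the core. Compound 3 `CC(=O)Oc1sccc1NC(=O)Nc1ccc(Oc2ccc(-c3ncc[nH]3)cc2)cc1` changes the other end instead: 2-acetoxythiophen-3-yl in place of 4-chloro-3-nitrophenyl on an amide-type nitrogen. No measured step touches this place, so the size and direction of the change in this assay cannot be read from the numbers shown. The expected value for compound 3 is therefore set near compound 2, 20% with a range of 3% to 50%, implying an expected step of a number 7.6 percentage points higher from compound 2 to compound 3 (within the scatter).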

Compound 3, percent growth inhibition at one concentration: 2.34%
Compound 3: the middle estimate sits 17.7 percentage points above what was measured; measured number below the stated range.
By their numbers in this assay, from the lowest: compound 3; then compound 2; then compound 1.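

Replacing 4-chloro-3-nitrophenyl with 2-acetoxythiophen-3-yl on an amide-type nitrogen gives, in this assay, a number 10.1 percentage points lower from compound 2 to compound 3 (beyond the scatter), so this place registers in the read-out even with the 1H-imidazol-2-yl group kept. With that group kept, this replacement brings no recovery of growth inhibition. No available data bear on the reason for this step.

Still open, from the compounds shown here alone, is how 2-acetoxythiophen-3-yl reads with the 1,3-thiazol-2-yl group in place of 1H-imidazol-2-yl. Also open, going by these compounds, is what a hydroxy group or an amine would give in place of the acetoxy group.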